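Adding a Hydroxy Group to the Propyl Chain

The compounds below may be only part of what the source reports. "The series", "measured", "known", "first", "only" and "open" are said of these compounds alone.

Of the compounds shown here, two have been measured in a functional assay on RAW264.7 cells (Mus musculus) for inhibition, read by Griess assay, with stated times of 2 h and 24 h; a higher number here means a weaker inhibitor, a lower number a stronger inhibitor. Compound 1 `CCCn1cc(COc2cc(O)c3c(c2)O[C@H](c2ccc(OC)c(O)c2)CC3=O)nn1` gives 9670 nM. Compound 2 `COc1ccc([C@@H]2C/C(=N\O)c3c(O)cc(OCc4cn(Cc5ccccc5C)nn4)cc3O2)cc1O` gives 18000 nM, a number within the scatter of compound 1, so compound 1 sits at the low end of the two without being separated from compound 2. Compound 3 `COc1ccc([C@@H]2CC(=O)c3c(O)cc(OCc4cn(CCCO)nn4)cc3O2)cc1O` has not yet been measured; it is built from compound 1 by hydroxy in place of hydrogen on a saturated chain carbon, three bonds along the chain from an aromatic nitrogen. Among the measured compounds shown here, no measured pair here differs in one place, so nothing measured shows how such a change moves the number. The step from compound 1 to compound 3 is expected to be a 1.0-fold lower number from compound 1 to compound 3 (0.01 log units; within the scatter), nothing beyond the scatter. Compound 3 is estimated at 9500 nM, between 3500 nM and 26000 nM.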

Compound 3, half-maximal inhibitory concentration: 16700 nM
Compound 3: middle estimate off by 1.8-fold (0.24 log units), on the low side, and the stated range covers the measured number.
By their numbers in this assay, from the lowest: compounds 1, 3 and 2 (each within the scatter of the next).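

Among the compounds shown here, this is the first measured pair that differs in one place, and it gives a direct reading of propyl to 3-hydroxypropyl in this assay (a 1.7-fold higher number from compound 1 to compound 3 (0.24 log units; within the scatter)). On this saturated chain carbon, three bonds along the chain from an aromatic nitrogen, hydroxy in place of hydrogen therefore leaves the number within the usual scatter of repeated measurements. No measurement at hand offers an explanation for this result. On these data alone, whether an amine or a carboxylic acid in place of the hydroxy, or a longer chain, would give a step beyond the scatter remains open.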